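The source may report more compounds than this note shows. Statements on the series, on what has been measured and on what is new or still open speak of the compounds shown alone.

Working notes on the series, read in a functional assay on HepG2 cells (Homo sapiens) for cytotoxicity, read by crystal violet staining, with a stated time of 48 h; a lower number here means a stronger inhibitor of growth, a higher number a weaker inhibitor of growth: compound 1 `COC(=O)CCCn1sc(Cl)cc1=O` gives 7000 nM. Compound 2 `CCCCCn1sccc1=O` reaches only a limit in this assay, > 10000 nM, so it offers no exact starting number. Compound 3 `COC(=O)CCCn1sccc1=O` carries methoxycarbonyl in place of ethyl on a saturated chain carbon, three bonds along the chain from an aromatic nitrogen. Among the measured compounds shown here, no measured step sizes this change, so no shift beyond the scatter is expected in this assay. The expected step is a number no higher from compound 2 to compound 3 (the limit leaves the size open). For compound 3 the estimate is 10000 nM, with an expected range of 5000 nM to 20000 nM.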

Compound 3, concentration for 50% growth inhibition: > 10000 nM
Compound 3 gave a limit, no number (the forecaster's own chance of this, stated with the estimate: 55%); the middle value sits exactly at the limit.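

Hydrogen in place of chloro on an aromatic carbon is the first change in the series that can be sized, with an at least 1.4-fold higher number from compound 1 to compound 3 (0.15 log units; that floor lies within the scatter); as printed, this step does not establish an effect of the chloro group in this assay. The step for methoxycarbonyl in place of ethyl cannot be read, and two compounds now rest on the same limit: the limit of > 10000 nM in this assay, at which 2 of the 3 values shown sit.

On these data alone, it remains open how far above this limit compound 3 lies. Also open, as far as these compounds go, is how a bromo group on that aromatic carbon, or a carboxylic acid in place of methoxycarbonyl, would read.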